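Carboxymethoxy for 3-Carboxypropyl: Expected Maximal Response

The source may hold more compounds than are shown below. What is called first, only, known or untested is meant among the compounds shown, and "the series" means these compounds.

Measured compounds:
compound 1, `O=C(O)CCCc1ccc(NCc2cccc(Oc3ccccc3)c2)cc1`: 59%
compound 2, `Cc1nc(-c2ccc(C(F)(F)F)cc2)sc1CNc1ccc(/C=C/C(=O)O)cc1`: 95%

In a functional assay on CHO cells for agonist activity at Free fatty acid receptor 1 (Homo sapiens), read by a luciferase reporter (a higher number here means a larger maximal response, a lower number a smaller maximal response), compound 1 gives 59%, the lowest of the two numbers. Compound 2 gives 95%, a number that lies above compound 1 by more than the usual scatter. For the measured compounds named here, the two compounds differ in several places at once, so no single step between them can be told from these values alone.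

Compound 3, `O=C(O)COc1ccc(NCc2cccc(Oc3ccccc3)c2)cc1`, differs from compound 1 in one place: carboxymethoxy in place of 3-carboxypropyl on an aromatic carbon. No change of exactly this kind has been measured here, and the nearest reference point is the value of compound 1. For compound 3 the step from compound 1 is expected to be small, downward if anything, and probably within the scatter: a number 4 percentage points lower from compound 1 to compound 3 (within the scatter). Compound 3 is therefore estimated at 55% in this assay, with a range from 35% to 80%.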

Compound 3, largest response reached (reported as percent of maximum), in percent of the reference or control that the assay uses: 84%
Beside the measured number, compound 3's estimate is 29 percentage points below it; measured number above the stated range.
By their numbers in this assay, from the lowest: compound 1; then compound 3; then compound 2.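

Carboxymethoxy in place of 3-carboxypropyl, on an aromatic carbon para to a large group, gives in this assay a number 25 percentage points higher from compound 1 to compound 3 (beyond the scatter). For the compounds shown here, this is the first single-place step, and it shows that the maximal response is sensitive to the group at this position: the entering group has 5 heavy atoms against 6 and 2 hydrogen-bond acceptors against 1, while each group has 1 hydrogen-bond donor and no ring. Nothing available ties the rise to any one of these differences.

From the compounds shown here alone, it remains open whether a 2-carboxyethyl group, with an all-carbon chain and no oxygen on the ring, would give a similar response, which would help separate the role of chain length from that of the oxygen. Going by these compounds, whether the same change would act alike on the core of compound 2 also remains open.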